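A few compounds are considered here, and "the series" means these few. Any claim that something is new, unique, unknown or untested is made for them only; others in the source may bear on it.

Measured so far:
compound 1 `O=c1cc(CNCc2ccccc2)oc2ccc(O)c(O)c12` — in an ADME assay on Huh-7 cells (Homo sapiens) for cytotoxicity (on this read-out lower numbers stand for higher toxicity in this test and higher numbers for lower toxicity in this test), compound 1 gives > 100000 nM, a limit of the assay.
compound 2 `O=c1cc(CNCc2ccc(F)cc2)oc2ccc(O)c(O)c12` — in this assay compound 2 gives > 100000 nM, again a limit of the assay.

Compound 2 thus stands at the limit of this assay, with no number of its own. Both values shown sit at that same limit (the limit of > 100000 nM in this assay, at which 2 of the 2 values shown sit). For the measured compounds named here, the one measured step, from compound 1 to compound 2, reads a step that the two limits leave unreadable from compound 1 to compound 2, so it yields no size for a change at that ring position. The change to compound 3 `O=c1cc(CNCc2ccc(O)cc2)oc2ccc(O)c(O)c12` is hydroxy in place of fluoro on an aromatic carbon. Going by the values given here, no measured step bears on it with a readable size; the two limits only show that both measured compounds lie outside the range of this assay. The expectation is therefore that compound 3 also stays at or beyond the limit, with no step beyond the scatter, a step that the limit leaves unreadable from compound 2 to compound 3. Compound 3 is estimated at 150000 nM, range 60000 nM to 500000 nM, most likely reported again as a limit.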

Compound 3, half-maximal cytotoxic concentration: 62700 nM
Beside the measured number, compound 3's estimate is 2.4-fold (0.38 log units) above it, within the range that was stated.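

In this assay compound 3 gives 62700 nM, so a hydroxy para to a large group brings a value inside the range of the read-out, which neither hydrogen nor fluoro at this position provided. Against fluoro the change reads as an at least 1.5-fold lower number from compound 2 to compound 3 (0.20 log units; that floor lies within the scatter), and against hydrogen it reads as an at least 1.5-fold lower number from compound 1 to compound 3 (0.20 log units; that floor lies within the scatter); both are only floors, and neither establishes a change beyond the scatter. The step from hydrogen to fluoro remains unreadable, and most of the series still sits at the edge of the read-out: the limit of > 100000 nM in this assay, at which 2 of the 3 values shown sit.

As far as these compounds go, whether an amine, a methoxy group or a carboxylic acid at this position would also give a value inside the range remains open. So does the true size of the hydroxy step, which needs a partner compound with a number of its own.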